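The compounds below may be only part of what the source reports. "The series", "measured", "known", "first", "only" and "open" are said of these compounds alone.

Measured in a functional assay on BXPC-3 cells (Homo sapiens) for cytotoxicity, read by MTT assay; on this read-out lower numbers stand for stronger inhibition and higher numbers for weaker inhibition:
compound 1 `Oc1ccc(CN(Cc2ccccc2)Cc2ccc(O)c3ncccc23)c2cccnc12`: 7440 nM
compound 2 `Oc1ccc(CN(Cc2ccccc2C(F)(F)F)Cc2ccc(O)c3ncccc23)c2cccnc12`: 274 nM

Compound 2 has the lower of the two numbers. Among the measured compounds shown here, the only measured step is a 27-fold lower number from compound 1 to compound 2 (1.43 log units; beyond the scatter), a large change on adding trifluoromethyl in place of hydrogen on an aromatic carbon. Compound 3 `Oc1ccc(CN(Cc2cccc(C(F)(F)F)c2)Cc2ccc(O)c3ncccc23)c2cccnc12` keeps the same atoms, joined differently: 3-(trifluoromethyl)phenyl in place of 2-(trifluoromethyl)phenyl on a saturated chain carbon bound to an amine nitrogen. For the measured compounds named here, no measured step covers such a change, so the large step above gives only a loose guide. Compound 3 still carries trifluoromethyl, so a value closer to compound 2 than to compound 1 is expected, with a modest loss. The estimated step is a 1.6-fold higher number from compound 2 to compound 3 (0.22 log units; within the scatter). The expected value for compound 3 is 450 nM, with an estimated range of 130 nM to 2000 nM.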

Compound 3, half-maximal inhibitory concentration: 167 nM
For compound 3 the middle estimate is 2.7-fold (0.43 log units) above the measured one; low and high end bracket the measured number.
By their numbers in this assay, from the lowest: compounds 3 and 2 (each within the scatter of the next); then compound 1.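

In this assay, moving the substituent from 2-(trifluoromethyl)benzyl to 3-(trifluoromethyl)benzyl gives a 1.6-fold lower number from compound 2 to compound 3 (0.22 log units; within the scatter), so this change does not separate compound 2 from compound 3. The gain over compound 1 is therefore not confined to one placement of trifluoromethyl, with a 45-fold lower number from compound 1 to compound 3 (1.65 log units; beyond the scatter) alongside a 27-fold lower number from compound 1 to compound 2 (1.43 log units; beyond the scatter). No measurement at hand accounts for this result.

Going by these compounds, whether a methoxy group or a chlorine atom in place of trifluoromethyl would give a comparable number stays open. Also open, on these data alone, is whether compound 2 and compound 3 stay this close in other cell lines.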